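The source may report more compounds than this note shows. Statements on the series, on what has been measured and on what is new or still open speak of the compounds shown alone.

Three compounds have been measured in a functional assay on A549 cells (Homo sapiens) for inhibition, read by CCK-8 assay, with a stated time of 72 h, tested at 8 uM; a lower number here means less inhibition of growth, a higher number more inhibition of growth at the concentration tested:

Compound 1 `COc1ccc(SCc2ccc(/C=C/C(=O)Nc3ccccc3N)cc2)cc1OC`: 80.6%
Compound 2 `Nc1ccccc1NC(=O)/C=C/c1ccc(CSc2ccc(Cl)cc2)cc1`: 59.6%
Compound 3 `Cc1ccc(SCc2ccc(/C=C/C(=O)Nc3ccccc3N)cc2)cc1`: 48.3%

Compound 3 stands lowest of the three in this assay, and its gap to each of the others lies beyond the usual scatter. The next compound, compound 4 `CC(C)(C)c1ccc(SCc2ccc(/C=C/C(=O)Nc3ccccc3N)cc2)cc1`, has tert-butyl in place of methyl on an aromatic carbon, para to a large group: tert-butyl in place of methyl on an aromatic carbon.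

The closest evidence comes from the change at that same aromatic carbon, where chloro gives way to methyl. This is a modest step, a number 11.3 percentage points lower from compound 2 to compound 3 (beyond the scatter). The wider changes of the group on sulfur are a number 21 percentage points lower from compound 1 to compound 2 (beyond the scatter), also modest, and a number 32.3 percentage points lower from compound 1 to compound 3 (beyond the scatter), which is large. Thus, the reading has responded to changes in this part of the molecule, and compound 3 is so far the low point. Neither of the other measured compounds carries a tert-butyl group, however, so the direction is only weakly supported.

A small rise is expected, one that may stay within the scatter, and the estimated change is a number 5.7 percentage points higher from compound 3 to compound 4 (within the scatter). The expected value for compound 4 is 54%, with an estimated range from 37% to 71%.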

Compound 4, percent growth inhibition at one concentration: 79.8%
Compound 4: the middle estimate sits 25.8 percentage points below what was measured, outside the stated range (above it).
By their numbers in this assay, from the lowest: compound 3; then compound 2; then compounds 4 and 1 (each within the scatter of the next).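

In this assay, the aromatic carbon para to a large group proves far more responsive than the earlier comparison of chloro and methyl had shown, as tert-butyl in place of methyl gives [ a number 31.5 percentage points higher from compound 3 to compound 4 (beyond the scatter) ]. Tert-butyl in place of chloro gives [ a number 20.2 percentage points higher from compound 2 to compound 4 (beyond the scatter) ], so the three groups at this carbon now rise in the order methyl, chloro, tert-butyl, which also shows that the reading does not simply follow the small step seen between the first two. The change of the whole group on sulfur gives [ a number 0.8 percentage points lower from compound 1 to compound 4 (within the scatter) ], so a 4-(tert-butyl)phenyl group, with a single substituent, and a 3,4-dimethoxyphenyl group, with two, cannot be told apart at the one concentration tested.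

Nothing at hand accounts for why tert-butyl reads so differently from methyl at this carbon. The compounds shown leave open how an isopropyl group, which would stand between methyl and tert-butyl, or an amine or a carboxylic acid at the same carbon would read, and whether the reading would continue to follow the group placed there.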